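The source may hold more compounds than are shown below. What is called first, only, known or untested is meant among the compounds shown, and "the series" means these compounds.

Working notes on the series. Three compounds have been run so far in a functional assay on the whole organism (stomach) for inhibition, with Canis familiaris (Canis lupus familiaris) as the target, at a dose of 8 mg/kg by the oral route; on this read-out lower numbers stand for a weaker effect and higher numbers for a stronger effect at the one dose given. Compound 1 `Cc1nc2c(/C=C\c3ccccc3)cccn2c1N` gives 4% in this assay. Compound 2 `Cc1nc2cc(/C=C/c3ccccc3)ccn2c1C` gives 0%. Compound 3 `Cc1nc2c(C/C=C\c3ccccc3)cccn2c1C` gives 0%.

Compound 3 stands level with compound 2 at the digits reported, the two together the lowest of the three numbers, and the gap to compound 1 is within the scatter, so no ordering among the three is supported by these numbers. Within the data shown here, nothing measured so far separates any compound from any other beyond the scatter.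

The next compound, compound 4 `Cc1nc2c(C/C=C\c3ccccc3)cccn2c1N`, differs from compound 3 in one place: amino in place of methyl on an aromatic carbon.

Among the measured compounds shown here, no pair among the measured compounds isolates this change on the present core. For the measured compounds named here, the only compound carrying the amino group, compound 1, sits within the scatter of compound 3 in this assay, and all three numbers lie near the floor of the read-out. The expected step from compound 3 to compound 4 in this assay is therefore none beyond the scatter, estimated as a number 3 percentage points higher from compound 3 to compound 4 (within the scatter). Compound 4 is expected to give about 3% in this assay, within a range from 0% to 15%.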

Compound 4, a percentage reported as inhibition, in the whole organism at one dose (the size of the read-out at that dose, not a potency): 0%
Estimate against measurement, compound 4: 3 percentage points above; the range from low to high includes it.
By their numbers in this assay, from the lowest: compounds 2, 3, 4 and 1 (each within the scatter of the next).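

Among these compounds, the first matched pair at this position gives, in this assay, no change at the digits printed from compound 3 to compound 4 (within the scatter), so amino in place of methyl on an aromatic carbon of the five-membered aromatic ring leaves the read-out unmoved on this core at the one dose given. Both members of the pair lie at the floor of the read-out, so neither group lifts this core off that floor, and the pair cannot tell whether the same change would matter on a compound with a stronger effect. No measurement at hand bears on why the read-out stays where it is.

On these data alone, whether any group at this place can give a read-out clear of the floor remains open, for instance a dimethylamino group or a carboxylic acid in place of the amino. Also open, as far as these compounds go, is whether a longer chain between the shared core and the phenyl ring, or a substituent such as a methoxy group on that phenyl ring, would give the amino and methyl groups a difference that can be read.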